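The source may hold more compounds than are shown below. What is called first, only, known or untested is meant among the compounds shown, and "the series" means these compounds.

Measured so far:
Compound 1, `[O-][S+](CCCCN=C=S)Cc1ccccc1`, gives 2850 nM in a functional assay on HepG2 cells (Homo sapiens) for cytotoxicity, read by MTT assay, with a stated time of 72 h; a higher number here means a weaker inhibitor, a lower number a stronger inhibitor.
Compound 2, `[O-][S+](CCCN=C=S)Cc1ccccc1`, gives 9840 nM in this assay.
Compound 3, `CC(C)[S+]([O-])CCCCCN=C=S`, gives 3690 nM in this assay.

Compounds 1 and 2 share one core; compound 3 has a different core, and the difference between the two cores is not broken down here. Within the first pair, the change from compound 2 to compound 1 is a group of 4 heavy atoms (2 carbon, 1 nitrogen, 1 sulfur; no ring) in place of a group of 3 heavy atoms (1 carbon, 1 nitrogen, 1 sulfur; no ring), on a saturated chain carbon, three bonds along the chain from a sulfur, and in this assay it made the step of a 3.5-fold lower number from compound 2 to compound 1 (0.54 log units; beyond the scatter). Compound 3 stands within the usual scatter of compound 1 in this assay, so no order between those two is claimed, while compound 3 sits beyond the scatter from compound 2.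

Compound 4, `CC(C)[S+]([O-])CCCCCCN=C=S`, has not yet been measured. It differs from compound 3 by a group of 4 heavy atoms (2 carbon, 1 nitrogen, 1 sulfur; no ring) in place of a group of 3 heavy atoms (1 carbon, 1 nitrogen, 1 sulfur; no ring), on a saturated chain carbon, five bonds along the chain from a sulfur. Within the data shown here, this is the same kind of change as the one from compound 2 to compound 1, but not the same: there it sat three bonds along the chain from a sulfur, here it sits five bonds along the chain from a sulfur, and the cores differ. Among the measured compounds shown here, because the only measured instance, a 3.5-fold lower number from compound 2 to compound 1 (0.54 log units; beyond the scatter), gave a modest step toward a lower number, a step of similar direction but uncertain size is expected here, estimated as a 1.8-fold lower number from compound 3 to compound 4 (0.27 log units; within the scatter). On that basis compound 4 is expected to give about 2000 nM in this assay, within a range from 800 nM to 5000 nM.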

Compound 4, half-maximal inhibitory concentration: 7820 nM
Estimate against measurement, compound 4: 3.9-fold (0.59 log units) below; the measured number lies above the stated range.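

In this assay, the same kind of chain change gives a 2.1-fold higher number from compound 3 to compound 4 (0.33 log units; beyond the scatter), whereas on the other core it gave a 3.5-fold lower number from compound 2 to compound 1 (0.54 log units; beyond the scatter). The change therefore does not carry over from one core to the other with a fixed direction, and a step measured on one core is a poor guide to the step on the other: the same change on two cores in this assay, a 3.5-fold lower number (0.54 log units; beyond the scatter) from compound 2 to compound 1 and a 2.1-fold higher number (0.33 log units; beyond the scatter) from compound 3 to compound 4, 7.3-fold (0.86 log units) apart, beyond the scatter of two such steps What this does not show is the reason for the reversal, since the two pairs differ both in their core and in the place of the change, three bonds along the chain from a sulfur in one and five bonds along the chain from a sulfur in the other, and one pair of each cannot separate these two differences or set a rule for the whole series.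

Still open, on these data alone, is how a longer chain would behave on the core of compound 1 and a shorter chain on the core of compound 3, which would allow chains of equal length to be compared on both cores. Also open, as far as these compounds go, is what an amine or a carboxylic acid would give in place of the nitrogen-and-sulfur group that all four compounds carry.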